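A few compounds are considered here, and "the series" means these few. Any claim that something is new, unique, unknown or untested is made for them only; others in the source may bear on it.

The measured compounds and their values:
Compound 1 `O=C(/N=C/c1ccccc1)Nc1ccc2c(c1)C(=O)C(=O)N2CN1CCCCC1` – 300 mg/kg
Compound 2 `O=C(/N=C/c1ccc(Cl)cc1)Nc1ccc2c(c1)C(=O)C(=O)N2CN1CCCCC1` – 300 mg/kg
Compound 3 `O=C(/N=C/c1ccccc1Cl)Nc1ccc2c(c1)C(=O)C(=O)N2CN1CCCCC1` – 300 mg/kg

All three were tested in a functional assay on the whole organism (strain Swiss albino) with Mus musculus as the target, with a stated time of 0.5 h; a lower number here means that less compound is needed, a higher number that more compound is needed for the effect. Compound 3 stands level with compound 1 and compound 2 at the digits given; its nearest neighbour is compound 1 and its furthest is compound 2, and neither separation goes beyond the scatter. The unmeasured compound 4 `O=C(/N=C/c1ccc(F)cc1)Nc1ccc2c(c1)C(=O)C(=O)N2CN1CCCCC1` differs from compound 3 in one place: 4-fluorophenyl in place of 2-chlorophenyl on a carbon with a double bond to nitrogen. Within the data shown here, three measured steps bear on this change, all touching the same phenyl group on the carbon with a double bond to nitrogen: no change at the digits printed from compound 1 to compound 2 (within the scatter), no change at the digits printed from compound 1 to compound 3 (within the scatter) and no change at the digits printed from compound 2 to compound 3 (within the scatter). Each of them left the minimum effective dose unchanged within the scatter, whether a chloro was added or moved. Among the measured compounds shown here, since every halogen change at this group so far produced no step in this assay, compound 4 is expected to show no step beyond the scatter either, no change at the digits printed from compound 3 to compound 4 (within the scatter). Compound 4 is therefore estimated at 300 mg/kg, with a range from 150 mg/kg to 600 mg/kg.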

Compound 4, minimum effective dose: 100 mg/kg
Compound 4: the middle estimate sits 3.0-fold (0.48 log units) above what was measured, outside the stated range (below it).
By their numbers in this assay, from the lowest: compound 4; then compounds 1, 2 and 3 (each within the scatter of the next).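

In this assay, among these compounds, fluoro in place of hydrogen on the phenyl group gives a 3.0-fold lower number from compound 1 to compound 4 (0.48 log units; beyond the scatter) and is the first change at this group to pass the scatter. Chloro did not do this, and the halogen itself counts at this place: fluoro in place of chloro gives a 3.0-fold lower number from compound 2 to compound 4 (0.48 log units; beyond the scatter) and 4-fluorophenyl in place of 2-chlorophenyl gives a 3.0-fold lower number from compound 3 to compound 4 (0.48 log units; beyond the scatter) on the same carbon with a double bond to nitrogen. Nothing available here explains why fluoro and chloro part at this group.

The compounds shown leave open whether the lower dose depends on where the fluoro sits, as 2-fluorophenyl would tell, or extends to a second fluoro, as in 2,4-difluorophenyl. They also leave open whether a methoxy group on the phenyl ring, or morpholine in place of piperidine, would shift the dose further.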